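The compounds below may be only part of what the source reports. "The series", "measured", "known", "first", "only" and "open" are said of these compounds alone.

Of the compounds shown here, two have so far been measured in a functional assay on KB cells (Homo sapiens), read by MTT assay; on this read-out higher numbers stand for weaker inhibition and lower numbers for stronger inhibition. Compound 1, `C=C[C@@]1(O)[C@@H](CO)O[C@@H](n2ccc(=O)[nH]c2=O)[C@@H]1O`, carries a vinyl group on a saturated ring carbon of its five-membered non-aromatic ring with 1 oxygen. In this assay compound 1 gives 51800 nM, the only number shown among the two compounds. Compound 2, `C#C[C@@H]1[C@@H](O)[C@H](n2ccc(=O)[nH]c2=O)O[C@@H]1CO`, is built differently on that ring. For compound 2 this assay reports only a limit, > 350000 nM, and this sits at the limit of > 350000 nM in this assay, at which 1 of the 2 values shown sits. Compound 3, `O=c1ccn([C@@H]2O[C@H](CO)[C@](O)(C3CC3)[C@H]2O)c(=O)[nH]1`, is not yet measured. It differs from compound 1 by cyclopropyl in place of vinyl on a saturated ring carbon. For the measured compounds named here, no measured pair shows this change, so its effect cannot be read off and can only be expected. Such a change is expected to leave the value close to that of compound 1, or to weaken inhibition slightly, within or just beyond the usual scatter of this assay. The step from compound 1 to compound 3 is estimated as a 1.5-fold higher number from compound 1 to compound 3 (0.19 log units; within the scatter). Compound 3 is therefore expected to give 80000 nM in this assay, within a range from 25000 nM to 300000 nM.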

Compound 3, half-maximal inhibitory concentration: > 350000 nM
Compound 3 ended at the assay's limit; the forecaster's own chance of this, stated with the estimate: 25%; at least 4.3-fold (0.64 log units) between middle value and limit.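

For the compounds shown here, for the first time, a single change at this saturated ring carbon can be read in this assay: cyclopropyl in place of vinyl gives an at least 6.7-fold higher number from compound 1 to compound 3 (0.82 log units; beyond the scatter). The position therefore does not treat these two groups alike, even though neither carries a hydrogen-bond donor, a hydrogen-bond acceptor or a net charge. Compound 3 gives only a limit and not a number, so the step has a lower bound but no known full size: the limit of > 350000 nM in this assay, at which 2 of the 3 values shown sit.

This single pair cannot tell whether the double bond of vinyl matters or whether the ring of cyclopropyl is what counts, and the compounds shown do not say how a plain ethyl group, a longer chain or an amine on the same carbon would fare. Going by these compounds alone, compound 2 is built differently on the ring and differs from compound 1 in more than one place, so it adds no step for this position.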